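The compounds below may be only part of what the source reports. "The series", "measured", "known", "first", "only" and "open" are said of these compounds alone.

Compound 1, with the structure `O=C(Nc1ccccc1)c1cccc(/C=C2\CC(=O)N(c3ccccc3)C2=O)c1`, was examined in an ADME assay on NCM460 cells (Homo sapiens) for cytotoxicity, read by MTT assay, with a stated time of 72 h; a higher number here means a weaker inhibitor, a lower number a stronger inhibitor. In this assay compound 1 gives > 100000 nM, which is a limit of the assay rather than a number. Compound 2, `COc1ccc(NC(=O)c2cccc(/C=C3\CC(=O)N(c4ccc(C)cc4)C3=O)c2)cc1`, was examined in the same way. In this assay compound 2 gives > 100000 nM, again a limit of the assay rather than a number. Within the data shown here, compound 1 therefore stands where every measured value here stands, namely at the limit of > 100000 nM in this assay, at which 2 of the 2 values shown sit, so no step between measured compounds can be read off and nothing is known about how any change shifts this read-out.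

Compound 3, `CSc1cccc(NC(=O)c2cccc(/C=C3\CC(=O)N(c4ccccc4)C3=O)c2)c1`, has not yet been measured. It differs from compound 1 by methylsulfanyl in place of hydrogen on an aromatic carbon, the new group sitting on an aromatic carbon of a six-membered aromatic ring of carbon only, meta to a large group. Among the measured compounds shown here, with both measured values at a limit, no step in this assay beyond the usual scatter is expected, in either direction. Compound 3 is expected to give about 120000 nM, between 50000 nM and 300000 nM, an expected step that the limit leaves unreadable from compound 1 to compound 3.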

Compound 3, half-maximal inhibitory concentration: > 100000 nM
Compound 3 gave a limit, no number; the forecaster's own chance of this, stated with the estimate: 75%; the middle value lies beyond the limit too.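

In this assay compound 3 also stands at a limit rather than a number, so no step from compound 1 to compound 3 can be read, because both sit at the same limit: the limit of > 100000 nM in this assay, at which 3 of the 3 values shown sit.

The compounds shown leave open whether methylsulfanyl in place of hydrogen on an aromatic carbon changes this read-out at all.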